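The compounds below may be only part of what the source reports. "The series", "measured", "known", "first", "only" and "open" are said of these compounds alone.

Compound 3, whose structure is `Cc1ccc(-c2ccc3ncc(-c4noc(C)n4)cc3c2)cc1`, was tested in a functional assay on RD cells (Homo sapiens) for inhibition, read by luminescence and ATP content, with a stated time of 72 h; a higher number here means that more compound is tolerated, a lower number that less compound is tolerated. In this assay compound 3 gives > 7400 nM, which is a limit of the assay rather than a number. Two close relatives have been tested alongside it. Compound 1, with the structure `Cc1nc(-c2cnc3ccc(-c4ccc(N)nc4)cc3c2)no1`, gives > 7400 nM in this assay, again a limit. Compound 2, with the structure `CCCc1ccc(-c2ccc3ncc(-c4noc(C)n4)cc3c2)cc1`, gives > 7400 nM in this assay, also a limit. The step from compound 1 to compound 3 reads a step that the two limits leave unreadable from compound 1 to compound 3, and the step from compound 2 to compound 3 reads a step that the two limits leave unreadable from compound 2 to compound 3; neither can be sized because both ends sit at the limit of > 7400 nM in this assay, at which 3 of the 3 values shown sit.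

Compound 4, whose structure is `Cc1nc(-c2cnc3ccc(-c4ccccc4)cc3c2)no1`, differs from compound 3 by hydrogen in place of methyl on an aromatic carbon. This is a small change on the same ring where the two unreadable steps were made, and nothing among the three measured compounds shows a value inside the measurable range. With all three neighbours at the limit, compound 4 is expected to stay at or beyond it as well, an expected step that the limit leaves unreadable from compound 3 to compound 4. Compound 4 is therefore estimated at 12000 nM, with a likely range from 5000 nM to 40000 nM.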

Compound 4, half-maximal cytotoxic concentration: > 2500 nM
Compound 4 was reported as a limit (the forecaster's own chance of this, stated with the estimate: 85%); the middle value does not contradict the limit.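

In this assay compound 4 gives > 2500 nM, a limit of the assay and not a number. The steps to compound 4 from compound 1, compound 2 and compound 3 cannot be read, as each joins two limits. The compounds shown leave open what the half-maximal cytotoxic concentration of any of the four actually is, and whether the changes among them shift it at all.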